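The source may hold more compounds than are shown below. What is called first, only, known or untested is meant among the compounds shown, and "the series" means these compounds.

Working notes on the series in an ADME assay on HeLa cells (Homo sapiens) for cytotoxicity, read by crystal violet staining, with a stated time of 72 h (on this read-out higher numbers stand for lower toxicity in this test and lower numbers for higher toxicity in this test), follow.

- compound 1 (`CCOC(=O)c1cc(CCCOc2ccc(-c3noc(C(F)(F)F)n3)cc2)on1`) gives > 100000 nM as a limit
- compound 2 (`CCOC(=O)c1cc(CCCOc2ccc(-c3noc(C(F)(F)F)n3)cc2[N+](=O)[O-])on1`) gives > 100000 nM as a limit
- compound 3 (`CCOC(=O)c1cc(CCCOc2c(OC)cc(-c3noc(C(F)(F)F)n3)cc2[N+](=O)[O-])on1`) gives > 100000 nM as a limit

Compound 2 has no number of its own and stands with the other two compounds at one limit (the limit of > 100000 nM in this assay, at which 3 of the 3 values shown sit). The next compound is compound 4 (`CCOC(=O)c1cc(CCCOc2ccc(-c3noc(C(F)(F)F)n3)cc2NC(C)=O)on1`), with acetamido in place of nitro on an aromatic carbon.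

For the measured compounds named here, two measured steps bear on this change. One is a step that the two limits leave unreadable from compound 1 to compound 2 at that same aromatic carbon, and the other is a step that the two limits leave unreadable from compound 2 to compound 3 on another aromatic carbon. Neither has a readable size, and neither gives a direction. Going by the values given here, the only guide is that all three compounds sit at the limit, and none departs from it.

The expected outcome is a number no higher from compound 2 to compound 4 (the limit leaves the size open) in this assay and no step beyond the scatter in either direction. Compound 4 is estimated at 100000 nM (expected range 40000 nM to 250000 nM) and will most probably be reported as a limit again.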

Compound 4, half-maximal cytotoxic concentration: > 100000 nM
Compound 4: only a limit was reported (the forecaster's own chance of this, stated with the estimate: 85%); the middle value sits exactly at the limit.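

In this assay compound 4 gives > 100000 nM, which is a limit. For the compounds shown here, no step from compound 1 or compound 2 to compound 4 can be read. The compounds shown leave open whether any of the substitutions changes the value, as all rest at one limit: the limit of > 100000 nM in this assay, at which 4 of the 4 values shown sit.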